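The compounds below may be only part of what the source reports. "The series", "measured", "known", "first", "only" and "open" are said of these compounds alone.

Compound 1 `Cc1nc(C(NC(=O)C(=O)Nc2ccc(Cl)cc2)C2CCCCN2C)sc1CCO`: 36000 nM
Compound 2 `Cc1nc(C(NC(=O)C(=O)Nc2ccc(F)cc2F)C2CCCCN2)sc1CCO`: > 84000 nM (a limit of the assay, not a number)

Among the measured compounds shown here, in an ADME assay on TZM-b1 cells (Homo sapiens) for cytotoxicity, read by XTT assay, with a stated time of 3 days (a higher number here means that more compound is tolerated, a lower number that less compound is tolerated), compound 1 gives 36000 nM, the only outright number among the two results. For compound 2 the result is the limit of > 84000 nM in this assay, at which 1 of the 2 values shown sits, a limit and not a number. Compound 3 `Cc1nc(C(NC(=O)C(=O)Nc2ccc(Cl)cc2)C2CCNCC2)sc1CCO` has not yet been measured; it differs from compound 1 in one place: piperidin-4-yl in place of 1-methylpiperidin-2-yl on a saturated chain carbon bound to an amide-type nitrogen and an aromatic carbon. The 1-methylpiperidin-2-yl gives way to a piperidin-4-yl, bringing in one hydrogen-bond donor. For the measured compounds named here, no step of this kind has been measured here, so its size can only be guessed. In this assay the step from compound 1 to compound 3 is expected to stay within the usual scatter, if anything leaning toward more compound being tolerated: a 1.4-fold higher number from compound 1 to compound 3 (0.14 log units; within the scatter). Compound 3 is therefore expected to give about 50000 nM, most likely between 20000 nM and 120000 nM.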

Compound 3, half-maximal cytotoxic concentration: 85400 nM
Beside the measured number, compound 3's estimate is 1.7-fold (0.23 log units) below it; low and high end bracket the measured number.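

Among the compounds shown here, this is the first measured step at this position, and in this assay replacing 1-methylpiperidin-2-yl with piperidin-4-yl gives a 2.4-fold higher number from compound 1 to compound 3 (0.38 log units; beyond the scatter). The group on this saturated chain carbon can therefore shift how much compound the cells tolerate, although the step is modest. The swap removes the methyl and moves the ring's attachment point at once, so the step cannot be credited to either change alone. Compound 2 differs from both other compounds in more than one place and holds a limit, not a number, so it adds no step: the limit of > 84000 nM in this assay, at which 1 of the 3 values shown sits.

The compounds shown leave open how piperidin-2-yl without its methyl, or 1-methylpiperidin-4-yl, would compare. They also leave open what an open-chain amine or a carboxylic acid would do at this position.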